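Compound 2 to compound 3: a new group on nitrogen

This account rests on a few compounds, and the source may have more. Where it says the series, first, only, none or still open, it means among the compounds named here.

In a functional assay on MDA-MB-468 cells (Homo sapiens) for inhibition (a higher number here means a weaker inhibitor of growth, a lower number a stronger inhibitor of growth), compound 1 (`C=C1C(=O)O[C@H]2[C@H]1CC/C(COC(=O)N1CCC(F)(F)CC1)=C\CC[C@@]1(C)O[C@@H]21`) gives 570 nM, and compound 2 (`C=C1C(=O)O[C@H]2[C@H]1CC/C(COC(=O)NCCN1CCCC1)=C\CC[C@@]1(C)O[C@@H]21`) gives 2300 nM, the higher of the two numbers. Compound 3 (`C=C1C(=O)O[C@H]2[C@H]1CC/C(COC(=O)Nc1n[nH]c(SC)n1)=C\CC[C@@]1(C)O[C@@H]21`) carries 5-(methylsulfanyl)-1H-1,2,4-triazol-3-yl in place of 2-(pyrrolidin-1-yl)ethyl on an amide-type nitrogen.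

For the measured compounds named here, one measured step bears on this change: a 4.0-fold higher number from compound 1 to compound 2 (0.61 log units; beyond the scatter), a modest step beyond the scatter, with (2-(pyrrolidin-1-yl)ethyl)amino in place of 4,4-difluoropiperidin-1-yl on a carbonyl carbon. Going by the values given here, no measured compound carries the entering group, so this step offers only a rough guide to size. Among the compounds with values here, a modest move towards a lower number in this assay is expected, no larger than that step. The expected change is a 1.9-fold lower number from compound 2 to compound 3 (0.28 log units; within the scatter). The estimated value for compound 3 is 1200 nM, with an expected range of 400 nM to 3500 nM.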

Compound 3, concentration for 50% growth inhibition: 1290 nM
Beside the measured number, compound 3's estimate is 1.1-fold (0.03 log units) below it, and the stated range covers the measured number.
By their numbers in this assay, from the lowest: compound 1; then compounds 3 and 2 (each within the scatter of the next).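

In this assay, the amide-type nitrogen accepts 5-(methylsulfanyl)-1H-1,2,4-triazol-3-yl with a 1.8-fold lower number from compound 2 to compound 3 (0.25 log units; within the scatter), so an aromatic ring with three hetero atoms and a chain-linked non-aromatic ring cannot be told apart at this position. The 4,4-difluoropiperidin-1-yl group on the carbonyl carbon still holds the lowest number, with a 2.3-fold higher number from compound 1 to compound 3 (0.35 log units; beyond the scatter), and both compounds that keep the amide hydrogen now lie above compound 1. Nothing available explains either step.

Open, from the compounds shown here alone, is whether the gap to compound 1 follows the amide hydrogen or the difluoropiperidine ring, which an unsubstituted piperidin-1-yl group or a simple methylamino group on the same carbonyl carbon would help separate. Also open, going by these compounds, is the part played by the methylsulfanyl group on the triazole, for which a plain methyl or an amine in its place would be informative.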